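The source may report more compounds than this note shows. Statements on the series, on what has been measured and on what is new or still open speak of the compounds shown alone.

Compound 1 `COc1ncnc2c1c(-c1ccoc1)cn2[C@@H]1O[C@H](CO)[C@@H](O)[C@H]1O`: 2820 nM
Compound 2 `Cc1ncnc2c1c(-c1ccoc1)cn2[C@@H]1O[C@H](CO)[C@@H](O)[C@H]1O`: > 20000 nM, a limit of the assay
Compound 3 `CNc1ncnc2c1c(-c1ccoc1)cn2[C@@H]1O[C@H](CO)[C@@H](O)[C@H]1O`: > 20000 nM, a limit of the assay

All three were tested in a functional assay on K562 cells (Homo sapiens), read by MTT assay, with a stated time of 72 h; on this read-out higher numbers stand for weaker inhibition and lower numbers for stronger inhibition. Compound 1 stands alone in giving a number; the two other values are limits (the limit of > 20000 nM in this assay, at which 2 of the 3 values shown sit). Compound 4 `COc1ncnc2c1c(-c1cc3ccccc3o1)cn2[C@@H]1O[C@H](CO)[C@@H](O)[C@H]1O` differs from compound 1 by 1-benzofuran-2-yl in place of furan-3-yl on an aromatic carbon. The measured steps, an at least 7.0-fold higher number from compound 1 to compound 2 (0.85 log units; beyond the scatter) and an at least 7.0-fold higher number from compound 1 to compound 3 (0.85 log units; beyond the scatter), both replace the methoxy on an aromatic carbon and leave the furan-3-yl untouched, so neither speaks to the change that leads to compound 4. Without a guide, the step expected is a 1.6-fold higher number from compound 1 to compound 4 (0.20 log units; within the scatter), a shift that may not exceed the scatter. Compound 4 is therefore estimated at 4500 nM, in a range from 1200 nM to 20000 nM.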

Compound 4, half-maximal inhibitory concentration: 13100 nM
Compound 4: middle estimate off by 2.9-fold (0.46 log units), on the low side, within the range that was stated.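

The earlier steps shown here all replaced the methoxy, whereas here the methoxy stays and the swap at the other aromatic carbon still moves the result in this assay: 1-benzofuran-2-yl in place of furan-3-yl gives a 4.6-fold higher number from compound 1 to compound 4 (0.67 log units; beyond the scatter). So this position also affects activity, and enlarging the group here weakens inhibition. Compound 4 still gives a number, but little room remains on this read-out: the limit of > 20000 nM in this assay, at which 2 of the 4 values shown sit.

A smaller furan-2-yl, a phenyl or a thiophene ring at this carbon could show whether the added six-membered ring or the changed attachment point matters. From the compounds shown here alone, whether the step would hold without the methoxy also stays open.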